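This account rests on a few compounds, and the source may have more. Where it says the series, first, only, none or still open, it means among the compounds named here.

Compound 1 `O=C(Nc1ncc(Cc2ccc(Br)cc2)s1)c1cccs1`: in an ADME assay on HepG2 2.2.15 cells (Homo sapiens) for cytotoxicity (on this read-out higher numbers stand for lower toxicity in this test and lower numbers for higher toxicity in this test), compound 1 gives > 50000 nM, a limit of the assay.
Compound 2 `CCCCCC(=O)Nc1ncc(C(Oc2ccc3cc(Br)ccc3c2)c2ccc(Cl)cc2)s1`: in this assay compound 2 gives > 50000 nM, a limit of the assay.
Compound 3 `COc1ccc(C(=O)Nc2ncc(C(Nc3cccc4ccccc34)c3ccc(Cl)cc3)s2)cc1`: in this assay compound 3 gives > 50000 nM, a limit of the assay.

Compound 2 stands, like the other two, only at a limit in this assay; no number is known for it, and nothing separates the three compounds, since (the limit of > 50000 nM in this assay, at which 3 of the 3 values shown sit). Compound 4 `O=S(=O)(Nc1ncc(C(Oc2ccc3cc(Br)ccc3c2)c2ccc(Cl)cc2)s1)c1ccccc1` differs from compound 2 in one place: phenylsulfonyl in place of pentylcarbonyl on a nitrogen on an aromatic ring. Among the compounds with values here, no step between measured compounds in this assay is known, so the change cannot be weighed against a precedent. Compound 4 is expected to behave as compound 2 does, with a step of a number no higher from compound 2 to compound 4 (the limit leaves the size open) not beyond the scatter, and most likely again only a limit. The estimate for compound 4 in this assay is 50000 nM, within 20000 nM to 100000 nM.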

Compound 4, half-maximal cytotoxic concentration: > 50000 nM
Compound 4 gave a limit, no number (the forecaster's own chance of this, stated with the estimate: 80%); the middle value sits exactly at the limit.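

No step can be read from compound 2 to compound 4, as both give only a limit: the limit of > 50000 nM in this assay, at which 4 of the 4 values shown sit. The compounds shown leave open what actual number any of them would reach in this assay, and whether any structural change would alter it.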